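This account rests on a few compounds, and the source may have more. Where it says the series, first, only, none or still open, it means among the compounds named here.

Compounds measured in a functional assay on SiHa cells (Homo sapiens) for cytotoxicity, with a stated time of 4 h; a lower number here means a stronger inhibitor, a higher number a weaker inhibitor:
compound 1, `CCN(CC)CCNc1n[n+]([O-])c2ccc(C)cc2[n+]1[O-]`: 300 nM
compound 2, `Cc1ccc2c(c1)[n+]([O-])c(NCCN1CCCCC1)n[n+]2[O-]`: 2200 nM
compound 3, `CCN(CC)CCNc1n[n+]([O-])c2ccc(C(C)C)cc2[n+]1[O-]`: 800 nM

Compounds 1 and 2 share a core and differ only in the amine at the chain end: piperidin-1-yl in place of diethylamino on a saturated chain carbon, two bonds along the chain from a nitrogen on an aromatic ring. That exchange gave a 7.3-fold higher number from compound 1 to compound 2 (0.87 log units; beyond the scatter). Compound 3 carries the same diethylamino chain as compound 1 but differs on the aromatic ring: isopropyl in place of methyl on an aromatic carbon. That change gave a 2.7-fold higher number from compound 1 to compound 3 (0.43 log units; beyond the scatter). Compound 4, `CC(C)c1ccc2c(c1)[n+]([O-])c(NCCN1CCCCC1)n[n+]2[O-]`, has not yet been measured in this assay. Going by the values given here, it differs from compound 3 by piperidin-1-yl in place of diethylamino on a saturated chain carbon, two bonds along the chain from a nitrogen on an aromatic ring, which is the same change as the one from compound 1 to compound 2, made on the core of compound 3 rather than on the core of compound 1; the place of the exchange is described in the same words in both cases.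

Among the compounds with values here, since the only measured instance of this exchange is the step from compound 1 to compound 2, compound 4 is expected to show a step of about a 6.3-fold higher number from compound 3 to compound 4 (0.80 log units; beyond the scatter) from compound 3 in this assay. That expectation rests on compound 1 and compound 2 alone, so it is held loosely. Compound 4 is therefore estimated at 5000 nM in this assay, with a range from 2000 nM to 15000 nM.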

Compound 4, half-maximal inhibitory concentration: 1100 nM
For compound 4 the middle estimate is 4.5-fold (0.66 log units) above the measured one; the measured number lies below the stated range.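

In this assay, the exchange of diethylamino for piperidin-1-yl gave a 1.4-fold higher number from compound 3 to compound 4 (0.14 log units; within the scatter), so the size of the step did not carry over from the core of compound 1 to the core of compound 3: the same change on two cores in this assay, a 7.3-fold higher number (0.87 log units; beyond the scatter) from compound 1 to compound 2 and a 1.4-fold higher number (0.14 log units; within the scatter) from compound 3 to compound 4, 5.3-fold (0.73 log units) apart, beyond the scatter of two such steps The exchange of methyl for isopropyl on an aromatic carbon read a 2.0-fold lower number from compound 2 to compound 4 (0.30 log units; within the scatter), so its step did not hold from one chain-end amine to the other either: the same change on two cores in this assay, a 2.7-fold higher number (0.43 log units; beyond the scatter) from compound 1 to compound 3 and a 2.0-fold lower number (0.30 log units; within the scatter) from compound 2 to compound 4, 5.3-fold (0.73 log units) apart, beyond the scatter of two such steps Within these compounds, the two exchanges therefore do not act independently, but this rests on a single closed set of compounds and shows neither the reason for the mismatch nor how the exchange would behave on any other core.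

From the compounds shown here alone, it remains open whether the same mismatch would appear with a chloro or methoxy group on that aromatic carbon. Also open, going by these compounds, is whether it would appear with morpholin-4-yl or pyrrolidin-1-yl at the chain end, or with a longer chain.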